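Sugar swap on the ring nitrogen of a cytotoxicity series

This account rests on a few compounds, and the source may have more. Where it says the series, first, only, none or still open, it means among the compounds named here.

Of the compounds shown here, two have been measured in a toxicity assay on L02 cells (Homo sapiens) for cytotoxicity, read by MTT assay, with a stated time of 72 h; on this read-out lower numbers stand for stronger inhibition and higher numbers for weaker inhibition. Compound 1 `O=C1c2c[n+]([O-])c3ccccc3c2C(=O)c2c1c1ccccc1n2Cc1cn([C@@H]2C[C@H](O)[C@@H](CO)O2)nn1` gives 630 nM, the lowest of the two numbers. Compound 2 `CN1CCN(CCCCCCn2c3c(c4ccccc42)C(=O)c2c[n+]([O-])c4ccccc4c2C3=O)CC1` gives 3800 nM, a gap from compound 1 beyond the scatter; these two differ in more than one place, so only the two values are set side by side. Compound 3 `O=C1c2c[n+]([O-])c3ccccc3c2C(=O)c2c1c1ccccc1n2Cc1cn([C@@H]2O[C@H](CO)[C@@H](O)[C@H](O)[C@H]2O)nn1` remains to be measured in this assay. It differs from compound 1 in one place: 3,4,5-trihydroxy-6-(hydroxymethyl)oxan-2-yl in place of 4-hydroxy-5-(hydroxymethyl)oxolan-2-yl on an aromatic nitrogen. Among the compounds with values here, no measured pair isolates such a change, so the size of the step is uncertain. The change is expected to move the number little, if at all beyond the scatter, with a slight lean toward a higher number; the expected step is a 1.4-fold higher number from compound 1 to compound 3 (0.15 log units; within the scatter). Compound 3 is estimated to give 900 nM, within a range from 350 nM to 2300 nM.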

Compound 3, half-maximal inhibitory concentration: 420 nM
Compound 3: the middle estimate sits 2.1-fold (0.33 log units) above what was measured; measured number inside the range.
By their numbers in this assay, from the lowest: compounds 3 and 1 (each within the scatter of the next); then compound 2.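

In this assay, the only step shown at this position is a 1.5-fold lower number from compound 1 to compound 3 (0.18 log units; within the scatter), which lies within the scatter. On this read-out, 3,4,5-trihydroxy-6-(hydroxymethyl)oxan-2-yl and 4-hydroxy-5-(hydroxymethyl)oxolan-2-yl on the aromatic nitrogen therefore cannot be told apart, even though the entering group has 11 heavy atoms against 8, 4 hydrogen-bond donors against 2, and a six-membered rather than a five-membered non-aromatic ring. Nothing at hand speaks to why the two groups read alike.

Whether a sugar is needed here at all remains open, since the compounds shown include no simple methyl group or primary amine on this aromatic nitrogen. Compound 2 differs from compound 1 in more than one place, so its value says nothing about this position.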